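Moving one bromine on a benzamide: compound 2 to compound 4

A few compounds are considered here, and "the series" means these few. Any claim that something is new, unique, unknown or untested is made for them only; others in the source may bear on it.

Compound 1 `O=C(Nc1cccc(Cl)c1)c1ccccc1O`: 37000 nM
Compound 2 `COc1ccc(Br)cc1C(=O)Nc1ccc(Sc2nc3ccccc3s2)cc1`: > 100000 nM (a limit, not a number)
Compound 3 `COc1c(Br)cc(Br)cc1C(=O)Nc1ccc(Sc2nc3ccccc3s2)c(Cl)c1`: > 100000 nM (a limit, not a number)

In an ADME assay on HEK293 cells (Homo sapiens) for cytotoxicity, read by reporter gene assay and resazurin assay, with a stated time of 48 h (on this read-out higher numbers stand for lower toxicity in this test and lower numbers for higher toxicity in this test), compound 1 gives a true number, 37000 nM. Compound 2 has no number, only a limit of the assay, > 100000 nM. Compound 3 likewise stands at a limit, > 100000 nM. Together these two make up (the limit of > 100000 nM in this assay, at which 2 of the 3 values shown sit).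

Compound 4 `COc1c(Br)cccc1C(=O)Nc1ccc(Sc2nc3ccccc3s2)cc1` has not yet been measured. It holds the same atoms as compound 2, joined differently: a group of 9 heavy atoms (7 carbon, 1 oxygen, 1 bromine; one six-membered aromatic ring of carbon only) in place of a group of 9 heavy atoms (7 carbon, 1 oxygen, 1 bromine; one six-membered aromatic ring of carbon only), on a carbonyl carbon. The 5-bromo-2-methoxyphenyl group leaves, and a group with no common name enters, on a carbonyl carbon.

Going by the values given here, no step between measured compounds is available to size such a change. The expectation therefore rests on compound 2 at its limit of > 100000 nM. The expected a number no higher from compound 2 to compound 4 (the limit leaves the size open) is none beyond the usual scatter, in either direction. Compound 4 is estimated at 100000 nM, with an expected range from 40000 nM to 200000 nM, and it may well be reported only as a limit.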

Compound 4, half-maximal cytotoxic concentration: > 100000 nM
Compound 4: no number, only a limit (the forecaster's own chance of this, stated with the estimate: 70%); the middle value sits exactly at the limit.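

Going by these compounds alone, compound 2 and compound 4 both stand at a limit in this assay, not at a number, and no step between them can be read. The compounds shown leave open whether moving the bromine changes the half-maximal cytotoxic concentration at all.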